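Urea Aryl Swap: Nitrophenyl to Bromo-Iodophenyl

The source may report more compounds than this note shows. Statements on the series, on what has been measured and on what is new or still open speak of the compounds shown alone.

Measured compounds:
- Compound 1 `Fc1ccc(C(CCCCOCc2ccc(Oc3ccc(Cl)cc3)cc2)c2ccc(F)cc2)cc1`: > 20000 nM
- Compound 2 `O=C(NCCCCC(c1ccc(F)cc1)c1ccc(F)cc1)Nc1cccc([N+](=O)[O-])c1`: 3790 nM

Within the data shown here, in a functional assay on MDA-MB-231 cells (Homo sapiens) for cytotoxicity, read by MTT assay, with a stated time of 48 h (on this read-out lower numbers stand for stronger inhibition and higher numbers for weaker inhibition), compound 2 gives 3790 nM, the only number reported here. For compound 1 the result is a limit, (the limit of > 20000 nM in this assay, at which 1 of the 2 values shown sits), so no number stands beside it. Compound 3 `O=C(NCCCCC(c1ccc(F)cc1)c1ccc(F)cc1)Nc1ccc(Br)cc1I` is not yet measured. It differs from compound 2 in one place: 4-bromo-2-iodophenyl in place of 3-nitrophenyl on an amide-type nitrogen. Among the measured compounds shown here, no step between two measured compounds is available, so the size and direction of this change cannot be read from any measured pair. The expected shift from compound 2 is therefore modest and without a firm direction, and the step of a 1.3-fold lower number from compound 2 to compound 3 (0.10 log units; within the scatter) is what this estimate implies. Compound 3 is expected to give about 3000 nM in this assay, with a likely range from 1000 nM to 10000 nM.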

Compound 3, half-maximal inhibitory concentration: > 20000 nM
Compound 3: a limit, no number (the forecaster's own chance of this, stated with the estimate: 10%); middle value at least 6.6-fold (0.82 log units) away from the limit.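

Among these compounds, the two compounds form the only measured pair here, and it shows that the aryl group on this amide-type nitrogen is not a neutral choice in this assay: 4-bromo-2-iodophenyl in place of 3-nitrophenyl gives an at least 5.2-fold higher number from compound 2 to compound 3 (0.72 log units; beyond the scatter). The result for compound 3 is a limit of the assay and not a number, so this step gives only a minimum size. Only compound 2 carries a true number here, which leaves little to rank: the limit of > 20000 nM in this assay, at which 2 of the 3 values shown sit.

The compounds shown cannot tell whether the step follows the loss of the nitro group, the arrival of the bromine or the arrival of the iodine, since all three come together. A phenyl ring carrying only bromine, only iodine, or an amine in place of the nitro group would separate these possibilities.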